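Swapping Trifluoromethyl for Tert-Butyl in an Anilide Series

The source may report more compounds than this note shows. Statements on the series, on what has been measured and on what is new or still open speak of the compounds shown alone.

Compound 1 `CCOC(=O)c1sc(-c2cccc(NC(=O)c3ccc(C(F)(F)F)cc3)c2)nc1Nc1ccc(N2CCN(C)CC2)cc1` is recorded as "not determined" (no result reported) in a functional assay on Ramos cells (Homo sapiens) for antiproliferative activity, read by CCK-8 assay, with a stated time of 72 h (on this read-out higher numbers stand for weaker inhibition and lower numbers for stronger inhibition), with no result reported. Among the measured compounds shown here, compound 2 `CN1CCN(c2ccc(Nc3nc(-c4cccc(NC(=O)c5ccc(C(F)(F)F)cc5)c4)sc3C(N)=O)cc2)CC1` gives 1580 nM in this assay and is the only compound with a number in hand, so it cannot be ranked against anything else; the one further entry carries no single number. Compound 3 `CN1CCN(c2ccc(Nc3nc(-c4cccc(NC(=O)c5ccc(C(C)(C)C)cc5)c4)sc3C(N)=O)cc2)CC1` differs from compound 2 in a single place: tert-butyl in place of trifluoromethyl on an aromatic carbon. For the measured compounds named here, no measured pair shows what this swap does in this assay, so any expectation rests on compound 2 alone. The expected step is a 1.1-fold lower number from compound 2 to compound 3 (0.02 log units; within the scatter), which means no change beyond the usual scatter in either direction, since the swapped groups match in size and in their lack of donors and acceptors as counted. Compound 3 is therefore estimated at 1500 nM in this assay, with a likely range from 500 nM to 4500 nM.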

Compound 3, half-maximal inhibitory concentration: 8600 nM
Compound 3: middle estimate off by 5.7-fold (0.76 log units), on the low side; measured number above the stated range.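

This position is not indifferent to the group it carries. In this assay, tert-butyl in place of trifluoromethyl on the aromatic carbon gives a 5.4-fold higher number from compound 2 to compound 3 (0.74 log units; beyond the scatter), a step towards weaker inhibition, although both groups have the same heavy-atom count and neither has a hydrogen-bond donor or acceptor. These matching counts therefore do not make the two groups interchangeable here, and nothing available explains why the change has this effect.

This single pair gives the size of one swap on one core, so it cannot show whether the step would hold on another core. It also leaves open how a chlorine atom, a methoxy group or a nitrile at this same place would compare with trifluoromethyl and tert-butyl.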